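The source may report more compounds than this note shows. Statements on the series, on what has been measured and on what is new or still open speak of the compounds shown alone.

Compound 1 `N#Cc1ccc(Nc2nc(Oc3ccccc3Cl)c3ccccc3n2)cc1` is the most cytotoxic of the three compounds measured in an ADME assay on MT4 cells (Homo sapiens) for cytotoxicity, read by MTT assay, with a stated time of 4 days (on this read-out lower numbers stand for higher toxicity in this test and higher numbers for lower toxicity in this test), where compound 1 gives 38000 nM. Compound 2 `COc1ccccc1Oc1nc(Nc2ccc(C#N)cc2)nc2ccccc12` gives 150000 nM in this assay, and compound 3 `COc1ccc(Oc2nc(Nc3ccc(C#N)cc3)nc3ccccc23)cc1` gives 340000 nM. Both changes away from the 2-chlorophenyl of compound 1 raised the number: a 3.9-fold higher number from compound 1 to compound 2 (0.60 log units; beyond the scatter) and an 8.9-fold higher number from compound 1 to compound 3 (0.95 log units; beyond the scatter), while a 2.3-fold higher number from compound 2 to compound 3 (0.36 log units; beyond the scatter).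

Compound 4 `Cc1cc(Br)c(Oc2nc(Nc3ccc(C#N)cc3)nc3ccccc23)c(Br)c1` differs from compound 1 in one place: 2,6-dibromo-4-methylphenyl in place of 2-chlorophenyl on an oxygen on an aromatic ring. The measured steps that start from compound 1 both replace chloro or the 2-chlorophenyl with a methoxy-bearing group, and in each case the number rose. The group entering in compound 4 carries two bromines and a methyl rather than a methoxy, so neither step matches it closely; they only show that this position can move the read-out by a modest amount. Compound 4 is therefore expected to stay near compound 1, with a 1.3-fold lower number from compound 1 to compound 4 (0.10 log units; within the scatter), and its estimate in this assay is 30000 nM, in the range 8000 nM to 120000 nM.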

Compound 4, half-maximal cytotoxic concentration: 25000 nM
For compound 4 the middle estimate is 1.2-fold (0.08 log units) above the measured one, within the range that was stated.
By their numbers in this assay, from the lowest: compounds 4 and 1 (each within the scatter of the next); then compound 2; then compound 3.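

In this assay, the larger 2,6-dibromo-4-methylphenyl on the oxygen leaves the read-out level with the 2-chlorophenyl of compound 1 (a 1.5-fold lower number from compound 1 to compound 4 (0.18 log units; within the scatter)). Both methoxy-bearing compounds stand clearly apart from compound 4 (a 6.0-fold lower number from compound 2 to compound 4 (0.78 log units; beyond the scatter); a 14-fold lower number from compound 3 to compound 4 (1.13 log units; beyond the scatter)), so across these four compounds the two halogen-bearing groups sit together at the low end, with compound 2 and compound 3 above them. Nothing shown here accounts for this grouping.

The compounds shown leave open whether the two bromines, the methyl or only their combination sets the number for compound 4. Going by these compounds, it also remains open how this read-out would respond to an amine or a carboxylic acid on the phenyl ring.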